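The source may hold more compounds than are shown below. What is called first, only, known or untested is meant among the compounds shown, and "the series" means these compounds.

Three compounds share one core and differ only at the amide-type nitrogen in the ring. In an assay on HEK293 cells for agonist activity at Toll-like receptor 8 (Homo sapiens), read by a luciferase reporter, with a stated time of 6 h (on this read-out lower numbers stand for an effect already at smaller amounts and higher numbers for an effect only at larger amounts of compound), compound 1 `CCCCNc1nc(N)nc2c1CCNC2` gives 0.6 uM. Compound 2 `CCCCNc1nc(N)nc2c1CN(C(C)=O)CC2` gives 0.5 uM, and compound 3 `CCCCNc1nc(N)nc2c1CN(Cc1ccc(C(F)(F)F)cc1)CC2` gives 0.23 uM. Compound 2 thus stands second highest of the three numbers, within the scatter of compound 1, while compound 3 shows a lower number beyond the scatter. Compound 4 `CCCCNc1nc(N)nc2c1CN(C(=O)c1cc(C)on1)CC2` is not yet measured; against compound 2 the change is 5-methyl-1,2-oxazol-3-yl in place of methyl on a carbonyl carbon. Within the data shown here, no measured pair shows this change. Because compound 3 reaches 0.23 uM with the largest substituent of the set, a modest downward step is expected, a 1.7-fold lower number from compound 2 to compound 4 (0.22 log units; within the scatter), though a result within the scatter is also plausible. Compound 4 is estimated at 0.3 uM, with a range from 0.1 uM to 1 uM.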

Compound 4, minimum effective concentration: 0.4 uM
For compound 4 the middle estimate is 1.3-fold (0.12 log units) below the measured one; low and high end bracket the measured number.
By their numbers in this assay, from the lowest: compounds 3, 4, 2 and 1 (each within the scatter of the next, the first and the last beyond it).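

In this assay, 5-methyl-1,2-oxazol-3-yl in place of methyl on a carbonyl carbon gives a 1.3-fold lower number from compound 2 to compound 4 (0.10 log units; within the scatter). This first pair differing in one place shows that this position accepts a five-membered aromatic ring with 2 hetero atoms without a step beyond the scatter. No supporting data explain this result.

Open, from the compounds shown here alone, is whether a phenyl ring at this place would stay within the scatter of compound 4, which would test the role of the hetero atoms. Also open, going by these compounds, is how a carboxylic acid or a longer chain in place of methyl would read out.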